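From compound 3 to compound 4: a slightly larger group

The source may report more compounds than this note shows. Statements on the series, on what has been measured and on what is new or still open speak of the compounds shown alone.

Measured so far in a functional assay on the whole organism for antagonist activity, with Rattus norvegicus as the target; on this read-out lower numbers stand for an effect already at smaller amounts and higher numbers for an effect only at larger amounts of compound:
- compound 1 `c1ccc2c(c1)CC(CCN1CCN(c3cccc4c3OCCO4)CC1)C2` gives 0.27 mg/kg
- compound 2 `C1=C(CCN2CCN(c3cccc4c3OCCO4)CC2)Cc2ccccc21` gives 0.36 mg/kg
- compound 3 `c1ccc2c(c1)CC2CN1CCN(c2cccc3c2OCCCO3)CC1` gives 0.32 mg/kg

Compound 3, at 0.32 mg/kg, lies within the usual scatter of both other compounds, so these three values cannot be ranked. Compound 4 `c1ccc2c(c1)CC2CCN1CCN(c2cccc3c2OCCCO3)CC1` has not yet been measured. The change from compound 3 is a group of 9 heavy atoms (9 carbon; one four-membered non-aromatic ring of carbon only, one six-membered aromatic ring of carbon only) in place of a group of 8 heavy atoms (8 carbon; one four-membered non-aromatic ring of carbon only, one six-membered aromatic ring of carbon only), on a saturated chain carbon bound to an amine nitrogen in a ring.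

Among the measured compounds shown here, no measured pair shows this exact change. The closest evidence is a 1.3-fold higher number from compound 1 to compound 2 (0.12 log units; within the scatter), where one carbon-only group replaces another of the same size on a saturated chain carbon. That step stayed within the scatter, but it is only a loose guide, since the group in compound 4 differs in size from the one it replaces. On that thin basis, no shift beyond the scatter is expected in this assay.

The estimated step is a 1.1-fold lower number from compound 3 to compound 4 (0.03 log units; within the scatter), which is expected to remain within the scatter.

For compound 4 the expected value is 0.3 mg/kg, with an estimated range from 0.11 mg/kg to 0.8 mg/kg.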

Compound 4, dose for 50% inhibition: 2.68 mg/kg
Compound 4: the middle estimate sits 8.9-fold (0.95 log units) below what was measured; the whole stated range lies below it.
By their numbers in this assay, from the lowest: compounds 1, 3 and 2 (each within the scatter of the next); then compound 4.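

In this assay, putting the group of 9 heavy atoms in place of the group of 8 heavy atoms, on a saturated chain carbon bound to an amine nitrogen in a ring, gives an 8.4-fold higher number from compound 3 to compound 4 (0.92 log units; beyond the scatter). A much larger dose of compound 4 is therefore needed, which shows that this position can respond strongly to a small difference in group size. The earlier step, between two groups of equal size, stayed within the scatter and gave no sign of this sensitivity, and nothing available here explains the new result.

Going by these compounds, this rests on a single pair, so it remains open whether the same change would matter as much on the core of compound 1. A longer chain at this place would show whether the number keeps rising as the group grows.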